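The source may hold more compounds than are shown below. What is called first, only, known or untested is meant among the compounds shown, and "the series" means these compounds.

Compound 1, `Cc1cc(C)cc(C(=O)N(NC(=O)c2ccccc2)C(C)(C)C)c1`: in an assay on cells for agonist activity at ecdysone receptor (Bombyx mori), read by a luciferase reporter, with a stated time of 24 h (a lower number here means that less compound is needed, a higher number that more compound is needed for the effect), compound 1 gives 69.2 nM.
Compound 2, `CC(C)(C)N(NC(=O)c1ccccc1I)C(=O)c1ccccc1Cl`: in this assay compound 2 gives 1290 nM.
Compound 3, `CCOc1ccccc1C(=O)N(NC(=O)c1ccc(CC)cc1)C(C)(C)C`: in this assay compound 3 gives 2880 nM.

Among these three numbers compound 2 stands second highest. Its nearest neighbour is compound 3, whose number is higher by a margin beyond the scatter; the furthest is compound 1, whose number is lower by a margin well beyond the scatter, so compound 2 needs more compound for the effect than compound 1 and less than compound 3.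

The unmeasured compound 4, `CCCCCCC(=O)NN(C(=O)c1ccccc1Cl)C(C)(C)C`, differs from compound 2 in one place: hexyl in place of 2-iodophenyl on a carbonyl carbon. For the measured compounds named here, no step between two measured compounds shows what this kind of change does in this assay; every measured compound carries an aromatic ring on that carbonyl carbon. The expectation therefore rests only on the fact that the aromatic ring is given up for an open chain, and a step upward, beyond the scatter, is expected, with the number for compound 4 in this assay estimated at 10000 nM, within a range of 2500 nM to 40000 nM. The step that this estimate means is expected to be a 7.8-fold higher number from compound 2 to compound 4 (0.89 log units; beyond the scatter).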

Compound 4, half-maximal effective concentration: 741 nM
Compound 4: the middle estimate sits 13-fold (1.13 log units) above what was measured, outside the stated range (below it).
By their numbers in this assay, from the lowest: compound 1; then compounds 4 and 2 (each within the scatter of the next); then compound 3.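

In this assay the carbonyl carbon whose other neighbour is the amide-type nitrogen tolerates an open chain, since hexyl in place of 2-iodophenyl gives a 1.7-fold lower number from compound 2 to compound 4 (0.24 log units; within the scatter) and so no real change. Every earlier compound carried an aromatic ring on this carbon, so they could not show that, with the rest of compound 2 held fixed, the ring is not needed to keep the number where it stands. Nothing available accounts for this match between a ring and an open chain.

As far as these compounds go, it remains open whether a shorter chain such as propyl, a longer chain such as decyl, or a chain ending in an amine or a carboxylic acid would behave like hexyl here. From the compounds shown here alone, it is also open whether hexyl would have the same outcome on the core of compound 1.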